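Second fluorine on the propoxy chain of compound 1

This account rests on a few compounds, and the source may have more. Where it says the series, first, only, none or still open, it means among the compounds named here.

Measured so far in a physicochemical assay for lipophilicity, read by NMR; on this read-out higher numbers stand for higher lipophilicity and lower numbers for lower lipophilicity:
- compound 1, `FCCCOc1ccc2[nH]ccc2c1`: 2.5
- compound 2, `CCCC(O)CF`: 0.74
- compound 3, `C[C@H](O)C[C@@H](C)F`: 0.48

Compound 1 gives the highest of the three numbers in this assay. The nearest number belongs to compound 2, which lies lower by a margin beyond the scatter; compound 3 is furthest, also lower by a margin beyond the scatter. Compounds 2 and 3 share no common edit with compound 1 or with each other, so their values serve only as points of reference, not as steps.

The new compound is compound 4, `FC(F)CCOc1ccc2[nH]ccc2c1`. It differs from compound 1 as follows: fluoro in place of hydrogen on a saturated chain carbon bound to a fluorine atom and a saturated chain carbon. The change adds one fluorine and no ring, donor, acceptor or charge, so the edit is small on any count.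

For the measured compounds named here, no measured pair in the set shows this change, so the expected size rests on the change itself and on the standing of compound 1. A modest upward step is expected, a number 0.25 log units higher from compound 1 to compound 4 (within the scatter), close to the edge of the scatter rather than clearly beyond it. Compound 4 is therefore estimated at 2.75 in this assay, within a range from 2.4 to 3.1.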

Compound 4, partition coefficient: 2.6
Compound 4: middle estimate off by 0.15 log units, on the high side, within the range that was stated.
By their numbers in this assay, from the lowest: compounds 3 and 2 (each within the scatter of the next); then compounds 1 and 4 (each within the scatter of the next).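

In this assay, for the compounds shown here, replacing the 3-fluoropropyl chain with the 3,3-difluoropropyl chain gives a number 0.10 log units higher from compound 1 to compound 4 (within the scatter) as the first single-change step, so the two compounds cannot be told apart on this read-out. At this saturated chain carbon, already bound to a fluorine atom, the added fluoro therefore produces no change that can be separated from the scatter, which compounds 2 and 3 could not show as they share no single edit with compound 1. Nothing measured here bears on why the step has this size.

This reading rests on one pair, one chain and one core, so it sets no rule for fluoro in place of hydrogen on other chains or in other surroundings. Going by these compounds, it remains open whether a 3,3,3-trifluoropropyl chain, a longer chain ending in the same difluoromethyl group, or a shorter 2,2-difluoroethyl chain would also stay within the scatter of compound 1, and whether an amine on the chain would move the number further than this fluoro does.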